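The source may hold more compounds than are shown below. What is called first, only, known or untested is meant among the compounds shown, and "the series" means these compounds.

Compound 1, with the structure `C=CC1=C(C(=O)NCCC)C(c2ccc(F)cc2)OC1`, gives in a functional assay on A549 cells (Homo sapiens) for cytotoxicity, read by MTT assay, with a stated time of 24 h (on this read-out higher numbers stand for weaker inhibition and lower numbers for stronger inhibition), only a limit, > 100000 nM.
Compound 2, with the structure `C=CC1=C(C(=O)NC2CCCCC2)C(c2ccc(OC)cc2)OC1`, gives in this assay only a limit, > 100000 nM.

Compound 2 therefore stands exactly where every value shown stands, at the limit of > 100000 nM in this assay, at which 2 of the 2 values shown sit, with no number of its own. Among the compounds with values here, no step between two measured compounds is available, so nothing measured tells how large the change to compound 3 might be. Compound 3, `C=CC1=C(C(=O)NCCC)C(c2ccc(OC)cc2)OC1`, differs from compound 2 by propyl in place of cyclohexyl on an amide-type nitrogen; cut one bond further out, the same difference reads cyclohexylamino to propylamino. Compound 3 thus carries the amide side of compound 1 on the remainder of compound 2, and both of those compounds sit at the limit of > 100000 nM in this assay, at which 2 of the 2 values shown sit, in this assay. The step from compound 2 to compound 3 is expected to be a step that the limit leaves unreadable from compound 2 to compound 3, nothing beyond the scatter. Compound 3 is expected to give 150000 nM in this assay, in the range 50000 nM to 500000 nM, most likely again as a limit only.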

Compound 3, half-maximal inhibitory concentration: > 100000 nM
Compound 3 was reported as a limit (the forecaster's own chance of this, stated with the estimate: 85%); the middle value is on the limit's open side.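

Compound 3 gives only a limit in this assay, so its steps from compound 1 and from compound 2 cannot be read: the limit of > 100000 nM in this assay, at which 3 of the 3 values shown sit.

The compounds shown leave open what propyl against cyclohexyl, or methoxy against fluoro, does to the read-out in this assay.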